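A few compounds are considered here, and "the series" means these few. Any claim that something is new, unique, unknown or untested is made for them only; others in the source may bear on it.

Measured compounds:
Compound 1 `O=C(Nc1cccc(C(F)(F)F)c1)c1cc(F)ccc1O`: 1800 nM
Compound 2 `O=C(Nc1ccc(OC(F)(F)F)c(Cl)c1)c1cc(Cl)ccc1O`: 1050 nM
Compound 3 `O=C(Nc1cccc(OC(F)(F)F)c1)c1cc(F)ccc1O`: 1370 nM

All three were tested in a functional assay on NALM-6 cells (Homo sapiens) for cytotoxicity, read by luminescence and CellTiter-Glo, with a stated time of 3 days; a higher number here means a weaker inhibitor, a lower number a stronger inhibitor. The three values sit close together, and the differences among them lie within the usual scatter. One change has already been measured: from compound 3 to compound 1, (trifluoromethyl in place of trifluoromethoxy on an aromatic carbon), which produced a 1.3-fold higher number from compound 3 to compound 1 (0.12 log units; within the scatter).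

Compound 4 `O=C(Nc1ccc(C(F)(F)F)c(Cl)c1)c1cc(Cl)ccc1O` is not yet measured. It is made from compound 2 by the same kind of change, (trifluoromethyl in place of trifluoromethoxy on an aromatic carbon), though the surroundings differ: here the carbon is ortho to a chloro group and para to a large group, whereas in compound 3 it is meta to a large group. The difference between the cores of compound 2 and compound 3 is not broken down here.

For compound 4 the step of a 1.2-fold higher number from compound 2 to compound 4 (0.09 log units; within the scatter) is expected, resting on the step from compound 3 to compound 1, a 1.3-fold higher number from compound 3 to compound 1 (0.12 log units; within the scatter). Compound 4 is therefore estimated at 1300 nM, with a range from 600 nM to 2800 nM.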

Compound 4, half-maximal inhibitory concentration: 1220 nM
The estimate for compound 4 lay 1.1-fold (0.03 log units) above the measured number; measured number inside the range.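

In this assay, trifluoromethyl in place of trifluoromethoxy gave a 1.2-fold higher number from compound 2 to compound 4 (0.07 log units; within the scatter) on this second core. Set beside the earlier case, the change behaved alike on the two cores: the same change on two cores in this assay, a 1.3-fold higher number (0.12 log units; within the scatter) from compound 3 to compound 1 and a 1.2-fold higher number (0.07 log units; within the scatter) from compound 2 to compound 4, 1.1-fold (0.05 log units) apart, within the scatter of two such steps. This shows that the swap left the number within the scatter on both cores, but with steps this small it does not show that a larger effect would carry over, and two cores cannot speak for the rest of the series.

The compounds shown leave open how an amine, a carboxylic acid or a longer chain would read in the same place. They also leave open whether any replacement there would move the number beyond the scatter.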